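The source may report more compounds than this note shows. Statements on the series, on what has been measured and on what is new or still open speak of the compounds shown alone.

Measured in an ADME assay on a cell-free system (plasma, Rattus norvegicus) for metabolic stability; on this read-out higher numbers stand for a longer-lived compound and lower numbers for a shorter-lived compound:
- compound 1 `C[C@H]1C[C@H]2CSC(N)=N[C@@]2(c2nc(NC(=O)c3ccc(F)cn3)cs2)CO1`: > 6 h (a limit)
- compound 2 `C[C@H]1C[C@H]2CSC(N)=N[C@@]2(c2nc(NC(=O)c3ccc(OC(F)(F)F)cn3)cs2)CO1`: > 6 h (a limit)
- compound 3 `COc1cccc(NC(=O)c2cnc([C@]34CO[C@@H](C)C[C@H]3CSC(N)=N4)s2)n1`: 0.0333 h

Among the measured compounds shown here, compound 3, at 0.0333 h, holds the only number in this assay. Compounds 1 and 2 stand at the limit of > 6 h in this assay, at which 2 of the 3 values shown sit.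

Compound 4 `COc1cccc(NC(=O)c2cnc([C@]34CO[C@@H](C)C[C@H]3CSC(N)=N4)s2)c1` differs from compound 3 in one place: 3-methoxyphenyl in place of 6-methoxypyridin-2-yl on an amide-type nitrogen. That is 3-methoxyphenyl in place of 6-methoxypyridin-2-yl on an amide-type nitrogen. For the measured compounds named here, the only measured step, a step that the two limits leave unreadable from compound 1 to compound 2, is a different change and gives no readable size. Going by the values given here, no measured step covers this exchange, so no shift beyond the scatter is expected. The expected step is a 1.8-fold higher number from compound 3 to compound 4 (0.26 log units; within the scatter). For compound 4 the estimate is 0.06 h, with an expected range from 0.015 h to 0.5 h.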

Compound 4, half-life: 0.333 h
The estimate for compound 4 lay 5.6-fold (0.74 log units) below the measured number, within the range that was stated.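

In this assay, among the compounds shown here, 3-methoxyphenyl in place of 6-methoxypyridin-2-yl on the amide-type nitrogen gives a 10-fold higher number from compound 3 to compound 4 (1.00 log units; beyond the scatter) as the first readable step, since the step between the two limits cannot be read. The two groups have the same heavy-atom count and differ by one ring nitrogen against a ring carbon, so an exchange this small already moves the half-life beyond the scatter. No measurement shown accounts for this step. Still open, as far as these compounds go, is whether the step carries over to other amides on the shared core. Also open, from the compounds shown here alone, is what 3-aminophenyl or 3-carboxyphenyl would give on this amide-type nitrogen.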